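Fluoro in Place of Hydrogen on the Benzyl Arm

A few compounds are considered here, and "the series" means these few. Any claim that something is new, unique, unknown or untested is made for them only; others in the source may bear on it.

Three compounds share the same core, a tert-butyl ester joined through a nitrogen that carries two arm groups. Compound 1 `CC(C)(C)OC(=O)CN(Cc1ccc(Cl)cc1)Cc1cnc[nH]1` carries a chlorobenzyl arm and an imidazole arm; in a functional assay on HEK293 cells for agonist activity at nuclear receptor subfamily 1 group D member 1 (Homo sapiens), read by a luciferase reporter, with a stated time of 24 h (a higher number here means that more compound is needed for the effect, a lower number that less compound is needed), compound 1 has the entry "not determined" (no result reported). Compound 2 `CC(C)(C)OC(=O)CN(Cc1ccc([N+](=O)[O-])cc1)Cc1ccc([N+](=O)[O-])s1` carries a nitrobenzyl arm and a nitrothiophene arm, and in this assay compound 2 gives 2500 nM. Compound 3 `CC(C)(C)OC(=O)CN(Cc1ccccc1)Cc1ccc([N+](=O)[O-])s1` keeps the nitrothiophene arm and has a plain benzyl arm; in this assay compound 3 has the entry "not determined" (no result reported), so no single number fixes where it stands, and the only number among these compounds belongs to compound 2.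

Compound 4 `CC(C)(C)OC(=O)CN(Cc1ccc(F)cc1)Cc1ccc([N+](=O)[O-])s1` differs from compound 3 in one place: fluoro in place of hydrogen on an aromatic carbon. With no measured step of this kind among these compounds, the change from compound 3 to compound 4 is expected to stay within the usual scatter, in no clear direction. Compound 4 is estimated to give about 2500 nM, with a range from 600 nM to 10000 nM.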

Compound 4, half-maximal effective concentration: 2000 nM
Estimate against measurement, compound 4: 1.3-fold (0.10 log units) above; the measured number falls inside the stated range.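

The step from compound 3 to compound 4 cannot be read, as compound 3 has no number in this assay to compare. The result instead gives a comparison on the same benzyl ring: with the nitrothiophene arm unchanged, putting fluoro in place of nitro gives a 1.3-fold lower number from compound 2 to compound 4 (0.10 log units; within the scatter) and so leaves the two compounds level. At this position, then, fluoro and nitro cannot be told apart in this assay, and a nitro group on the benzyl ring is not required for a measurable value.

On these data alone, whether an amine or a carboxylic acid at this position would shift the value beyond the scatter remains open, as does the effect of fluoro compared with plain hydrogen. No measurement shown explains why fluoro and nitro give such similar results.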